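This account rests on a few compounds, and the source may have more. Where it says the series, first, only, none or still open, it means among the compounds named here.

Of the compounds shown here, two built on one shared core have been measured in a functional assay on the whole organism (artery, strain albino) with Rattus norvegicus as the target, with a stated time of 600 min, at a dose of 10 mg/kg by the oral route; a higher number here means more inhibition at the dose given (going by the name of the read-out), a lower number less inhibition. Compound 1 `CC1=C(C(=O)Nc2ccc([N+](=O)[O-])cc2)C(c2ccc(Br)cc2)N=C(SCc2ccccc2)N1` gives 27.2%. Compound 2 `CC1=C(C(=O)Nc2ccc([N+](=O)[O-])cc2)C(c2cccc([N+](=O)[O-])c2)N=C(SCc2ccccc2)N1` carries a 3-nitrophenyl in place of the 4-bromophenyl of compound 1 on a saturated ring carbon. In this assay compound 2 gives 27.2%. The step of no change at the digits printed from compound 1 to compound 2 (within the scatter) shows that this swap leaves the read-out unchanged within the scatter, so compound 2 stands level with compound 1 and is the only reference point available.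

Compound 3 `CC1=C(C(=O)Nc2ccc([N+](=O)[O-])cc2)C(c2cccc([N+](=O)[O-])c2)N=C(SCc2ccc(Cl)cc2)N1` has not yet been measured. Relative to compound 2 it differs by chloro in place of hydrogen on an aromatic carbon: the benzylsulfanyl arm of compound 2 becomes a (4-chlorobenzyl)sulfanyl arm, and nothing else changes. Among the measured compounds shown here, no measured step touches this arm; the single step that exists, from compound 1 to compound 2, alters a different part of the core and stayed within the scatter. With nothing pointing toward a rise or a fall, the expected step of a number 0.2 percentage points lower from compound 2 to compound 3 (within the scatter) is one that stays within the scatter. Compound 3 is therefore estimated at 27%, with a likely range from 15% to 40%.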

Compound 3, a percentage reported as inhibition, in the whole organism at one dose (the size of the read-out at that dose, not a potency): 26.2%
Compound 3: middle estimate off by 0.8 percentage points, on the high side, and the stated range covers the measured number.
By their numbers in this assay, from the lowest: compounds 3, 1 and 2 (each within the scatter of the next).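

In this assay, among the compounds shown here, the step of a number 1 percentage points lower from compound 2 to compound 3 (within the scatter) gives the first reading on the benzylsulfanyl arm, a part of the molecule that the earlier pair left untouched. Changing benzyl to 4-chlorobenzyl therefore does not separate the two compounds at this single oral dose, and together with the step of no change at the digits printed from compound 1 to compound 2 (within the scatter) it means that swaps at two different places on the shared core have each stayed within the scatter. No other measurement here bears on why this chloro swap leaves the read-out within the scatter.

The 4-chlorobenzyl arm is the only substituted version of this arm among the compounds shown, so it remains open whether a different group on the same aromatic ring, such as an amine or a carboxylic acid, would give a reading beyond the scatter. From the compounds shown here alone, it is also open whether a longer chain in place of the benzyl would move the read-out, and a reading at one dose says nothing about how the compounds would compare at other doses.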